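This account rests on a few compounds, and the source may have more. Where it says the series, first, only, none or still open, it means among the compounds named here.

Values so far in a functional assay on MC-38 cells (Mus musculus) for antiproliferative activity; on this read-out higher numbers stand for weaker inhibition and lower numbers for stronger inhibition

Compound 1 `COc1ccc(S(=O)(=O)Nc2cccc3c(C#N)c[nH]c23)cc1` gives 0.17 ug/mL
Compound 2 `N#Cc1c[nH]c2c(NS(=O)(=O)c3ccc(N)cc3)cccc12` gives 0.28 ug/mL

Within the data shown here, compound 2, at 0.28 ug/mL, stands within the scatter of compound 1, the only other compound measured. Compound 3 `CS(=O)(=O)Nc1ccc(S(=O)(=O)Nc2cccc3c(C#N)c[nH]c23)cc1` is compound 2 with methylsulfonyl in place of hydrogen on a nitrogen on an aromatic ring, so the amino group becomes methanesulfonamido. Among the measured compounds shown here, only one measured step bears on this (a 1.6-fold higher number from compound 1 to compound 2 (0.22 log units; within the scatter)), and in it amino takes the place of methoxy on an aromatic carbon. For the measured compounds named here, that step is small, but no measured compound carries methylsulfonyl, so the evidence is thin. In this assay no step beyond the scatter is therefore expected, and the estimated change is slight (a 1.1-fold higher number from compound 2 to compound 3 (0.03 log units; within the scatter)). Compound 3 is estimated at 0.3 ug/mL with an expected range from 0.1 ug/mL to 0.9 ug/mL as the likely span.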

Compound 3, half-maximal inhibitory concentration: 1.2 ug/mL
For compound 3 the middle estimate is 4.0-fold (0.60 log units) below the measured one, and the stated range ends below it.
By their numbers in this assay, from the lowest: compounds 1 and 2 (each within the scatter of the next); then compound 3.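

In this assay, among these compounds, putting methylsulfonyl on the nitrogen of the amino group gives a 4.3-fold higher number from compound 2 to compound 3 (0.63 log units; beyond the scatter), the first change in this short series that clearly weakens inhibition. Replacing methoxy with methanesulfonamido on the same aromatic carbon gives a 7.1-fold higher number from compound 1 to compound 3 (0.85 log units; beyond the scatter), so this site does respond to its substituent, even though the swap between methoxy and amino stayed within the scatter. Nothing available explains why the larger group weakens inhibition.

The compounds shown leave open whether the loss belongs to methylsulfonyl in particular or would also follow from another group on that nitrogen, such as acetyl or a plain methyl. They also leave open how a group without that nitrogen, such as a carboxylic acid at the same site, would behave.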